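Turning the Amide Around and Swapping Phenyl for Thiophene

A few compounds are considered here, and "the series" means these few. Any claim that something is new, unique, unknown or untested is made for them only; others in the source may bear on it.

Measured so far:
compound 1, `Cc1nn(-c2ncnc3nc[nH]c23)c2c1C(OC1CCCC1)CC(=O)N2`: 62 nM
compound 2, `Cc1nn(-c2ncnc3nc[nH]c23)c2c1C(C(=O)NCc1ccccc1)CC(=O)N2`: 2930 nM

In a functional assay on HEK293 cells for agonist activity at G-protein coupled receptor 39 (Homo sapiens), read by scintillation proximity assay and inositol phosphate accumulation, with a stated time of 75 min (on this read-out lower numbers stand for an effect already at smaller amounts and higher numbers for an effect only at larger amounts of compound), compound 1 gives 62 nM, while compound 2 gives 2930 nM. For the measured compounds named here, the single measured step is a 47-fold higher number from compound 1 to compound 2 (1.67 log units; beyond the scatter). Among the numbers shown, compound 2 stands highest, and its nearest neighbour is compound 1 with a far lower number.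

Compound 3, `Cc1nn(-c2ncnc3nc[nH]c23)c2c1C(NC(=O)Cc1cccs1)CC(=O)N2`, has not been measured. Compared with compound 2, the change is (((thiophen-2-yl)methyl)carbonyl)amino in place of benzylcarbamoyl on a saturated ring carbon. In plain terms the amide is reversed and the phenyl ring gives way to a thiophene ring. Going by the values given here, no measured step on this core covers either of those changes; the only step on record, the exchange of cyclopentyloxy for benzylcarbamoyl at the same carbon, speaks to a different kind of group and gives no direction for this one. With nothing comparable to lean on, the estimate for compound 3 stays close to compound 2. This means an expected step of a 2.0-fold lower number from compound 2 to compound 3 (0.29 log units; within the scatter), within the scatter. Compound 3 is thus expected to give about 1500 nM, with a likely range from 300 nM to 7000 nM.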

Compound 3, half-maximal effective concentration: 244 nM
For compound 3 the middle estimate is 6.1-fold (0.79 log units) above the measured one; the measured number lies below the stated range.
By their numbers in this assay, from the lowest: compound 1; then compound 3; then compound 2.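

In this assay, the new result shows that a carbonyl-and-nitrogen linkage at this saturated ring carbon is not in itself tied to a high number, since the step is large: a 12-fold lower number from compound 2 to compound 3 (1.08 log units; beyond the scatter). The (((thiophen-2-yl)methyl)carbonyl)amino group still falls short of cyclopentyloxy, with a 3.9-fold higher number from compound 1 to compound 3 (0.59 log units; beyond the scatter), so among these three compounds the lowest number stays with the ether-linked cyclopentyl group. Two things changed together in this step, the direction of the amide and the ring at its end, and no other data here explain the size of the drop.

The compounds shown therefore leave open how much of the step belongs to turning the amide around and how much to the thiophene, a question that a phenylacetylamino group at this carbon, with the reversed amide and a phenyl ring, would help to separate. They also leave open how a longer chain between the carbonyl and the thiophene, or a thiophen-3-yl ring in place of thiophen-2-yl, would read out in this assay.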